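The compounds below may be only part of what the source reports. "The series", "measured", "known", "first", "only" and "open" are said of these compounds alone.

Measured so far in an assay on LX2 cells for inhibition of COL1A1 promoter (Homo sapiens), read by a luciferase reporter, with a stated time of 24 h, tested at 20 uM; a lower number here means a weaker effect, a higher number a stronger effect of the compound at the concentration tested:
compound 1 `Cc1ccc(-n2cc(C(=O)Nc3cc(F)cc(F)c3)c(=O)c3ccc(N(C)C)nc32)cc1OCCCCCCC[N+]1(C)CCCC1` gives 12.7%;
compound 2 `CN(C)c1ccc2c(=O)c(C(=O)Nc3cc(F)cc(F)c3)cn(-c3ccc(Cl)c(OCCCCCCC[N+]4(C)CCCC4)c3)c2n1` gives 51%;
compound 3 `Cc1ccc(-n2cc(C(=O)Nc3cc(F)cc(F)c3)c(=O)c3ccc(N(C)C)nc32)cc1OCCCCCCC[N+]1(C)CCCCC1` gives 23.4%.

Compound 4 `CN(C)c1ccc2c(=O)c(C(=O)Nc3cc(F)cc(F)c3)cn(-c3ccc(Cl)c(OCCCCCCC[N+]4(C)CCCCC4)c3)c2n1` has not yet been measured. It differs from compound 3 by chloro in place of methyl on an aromatic carbon. This change has already been measured once, as chloro in place of methyl on an aromatic carbon, where it gave a number 38.3 percentage points higher from compound 1 to compound 2 (beyond the scatter). The place is described in the same words both times, so it is the same change carried onto a different core. The cores of compound 1 and compound 3 differ by a group of 7 heavy atoms (6 carbon, 1 nitrogen; one six-membered non-aromatic ring with 1 hetero atom) in place of a group of 6 heavy atoms (5 carbon, 1 nitrogen; one five-membered non-aromatic ring with 1 hetero atom), on a saturated chain carbon, seven bonds along the chain from an oxygen on an aromatic ring, a change that on its own gave a number 10.7 percentage points higher from compound 1 to compound 3 (beyond the scatter). Because a number 38.3 percentage points higher from compound 1 to compound 2 (beyond the scatter) was large, a step of similar size is expected here, namely a number 34.6 percentage points higher from compound 3 to compound 4 (beyond the scatter), resting on that single earlier instance. Compound 4 is therefore expected to give about 58%, with a likely range from 40% to 75%.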

Compound 4, a percentage reported as inhibition, at one concentration (the size of the read-out at that concentration, not a potency): 57.3%
Compound 4: middle estimate off by 0.7 percentage points, on the high side, and the stated range covers the measured number.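

In this assay, chloro in place of methyl gives a number 33.9 percentage points higher from compound 3 to compound 4 (beyond the scatter), and the step keeps its size on the second core: the same change on two cores in this assay, a number 38.3 percentage points higher (beyond the scatter) from compound 1 to compound 2 and a number 33.9 percentage points higher (beyond the scatter) from compound 3 to compound 4, 4.4 percentage points apart, within the scatter of two such steps. The six-membered non-aromatic ring in place of the five-membered one gives a number 6.3 percentage points higher from compound 2 to compound 4 (within the scatter), which agrees with its earlier step: the same change on two cores in this assay, a number 10.7 percentage points higher (beyond the scatter) from compound 1 to compound 3 and a number 6.3 percentage points higher (within the scatter) from compound 2 to compound 4, 4.4 percentage points apart, within the scatter of two such steps. Going by these compounds alone, this shows that in these four compounds the two changes add up independently of each other, but it rests on only two cores and one read-out at a single concentration, and it does not show why chloro has this effect or that the step would hold on other cores.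

Going by these compounds, it remains open whether fluoro, bromo or methoxy in that place would behave like chloro. Also open, on these data alone, is how a morpholine ring or a shorter chain would change the read-out.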